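A few compounds are considered here, and "the series" means these few. Any claim that something is new, unique, unknown or untested is made for them only; others in the source may bear on it.

The two measured compounds in an in vitro assay on Sf21 cells for inhibition of high affinity 3',5'-cyclic-AMP phosphodiesterase 7A (Homo sapiens), read by scintillation proximity assay, with a stated time of 30 min; on this read-out higher numbers stand for weaker inhibition and lower numbers for stronger inhibition:
compound 1 `O=C(O)Cc1ccc(NC(=O)c2cn(Cc3c(F)cccc3F)c3ccc(=O)[nH]c3c2=O)cc1`: 176 nM
compound 2 `O=C(Nc1ccc(C(=O)N2CCOCC2)cc1)c1cn(Cc2c(F)cccc2F)c2ccc(=O)[nH]c2c1=O`: 188 nM

Among the compounds with values here, compound 2 stands at one end of these two numbers, with compound 1 as its only neighbour, and the step of a 1.1-fold higher number from compound 1 to compound 2 (0.03 log units; within the scatter) lies within the scatter, so the two values cannot be told apart on this assay.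

Compound 3 `CS(=O)(=O)c1ccc(NC(=O)c2cn(Cc3c(F)cccc3F)c3ccc(=O)[nH]c3c2=O)cc1` is the next compound. Compared with compound 2 the change is methylsulfonyl in place of (morpholin-4-yl)carbonyl on an aromatic carbon. Within the data shown here, only one measured step bears on this position: the exchange of carboxymethyl for (morpholin-4-yl)carbonyl on the same aromatic carbon, a 1.1-fold higher number from compound 1 to compound 2 (0.03 log units; within the scatter), which did not move the number beyond the scatter. Among the measured compounds shown here, no measured step introduces methylsulfonyl, so the new group itself is untested. Given that a change of substituent at this aromatic carbon left the number essentially unchanged, compound 3 is expected to show a step of a 1.1-fold higher number from compound 2 to compound 3 (0.03 log units; within the scatter), that is, none beyond the scatter in this assay. The estimate for compound 3 is 200 nM, with a range from 70 nM to 600 nM.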

Compound 3, half-maximal inhibitory concentration: 27 nM
For compound 3 the middle estimate is 7.4-fold (0.87 log units) above the measured one; the measured number lies below the stated range.
By their numbers in this assay, from the lowest: compound 3; then compounds 1 and 2 (each within the scatter of the next).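

In this assay this aromatic carbon, para to a large group, turns out not to be indifferent to its substituent: methylsulfonyl gives a 7.0-fold lower number from compound 2 to compound 3 (0.84 log units; beyond the scatter) against (morpholin-4-yl)carbonyl and a 6.5-fold lower number from compound 1 to compound 3 (0.81 log units; beyond the scatter) against carboxymethyl. The earlier exchange between those two groups could not be told apart from the scatter, so the position had looked flat, whereas the three compounds together show that the number here depends on which group is present. Nothing at hand accounts for why methylsulfonyl stands apart from the other two groups.

From the compounds shown here alone, with a single compound at the lower number, it remains open whether the difference belongs to methylsulfonyl itself, to the loss of the six-membered non-aromatic ring, or to the lower count of heavy atoms, as all of these arrive together in one exchange. Going by these compounds, it also remains open whether a sulfonamide, a nitrile or an ethylsulfonyl group on this aromatic carbon would keep the lower number, and whether a change elsewhere on the shared core would act the same way alongside methylsulfonyl.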